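Side-chain swaps at the amide-linked carbon of the benzyl ester

This account rests on a few compounds, and the source may have more. Where it says the series, first, only, none or still open, it means among the compounds named here.

Measured compounds:
compound 1 `CC(C)[C@H](NC(=O)CN(c1ncnc2c1ncn2C1CCCCO1)C1CC1)C(=O)OCc1ccccc1` — 25.8%
compound 2 `NC(=O)CC[C@H](NC(=O)CN(c1ncnc2c1ncn2C1CCCCO1)C1CC1)C(=O)OCc1ccccc1` — 22.3%
compound 3 `O=C(CN(c1ncnc2c1ncn2C1CCCCO1)C1CC1)N[C@@H](CCC(=O)OCc1ccccc1)C(=O)OCc1ccccc1` — 20.7%

In a functional assay on the whole organism (Tail, strain ICR) with Mus musculus as the target, in the tail flick test, with a stated time of 120 min, at a dose of 25 umol/kg by the oral route (on this read-out lower numbers stand for a weaker effect and higher numbers for a stronger effect at the one dose given), compound 3 gives the lowest of the three numbers, yet both compound 2 and compound 1 sit within the scatter of it, so the three values cannot be told apart. Compound 4 is `C[C@@H](O)[C@H](NC(=O)CN(c1ncnc2c1ncn2C1CCCCO1)C1CC1)C(=O)OCc1ccccc1`; relative to compound 3 the change is 1-hydroxyethyl in place of 2-(benzyloxycarbonyl)ethyl on a saturated chain carbon bound to an amide-type nitrogen and a carbonyl carbon. For the measured compounds named here, the steps that bear on this change all alter the same carbon: a number 5.1 percentage points lower from compound 1 to compound 3 (within the scatter), a number 1.6 percentage points lower from compound 2 to compound 3 (within the scatter) and a number 3.5 percentage points lower from compound 1 to compound 2 (within the scatter). Each such exchange stayed within the scatter, so for compound 4 no step beyond the scatter is expected: a number 3.3 percentage points higher from compound 3 to compound 4 (within the scatter). Compound 4 is accordingly estimated at 24%, in the range 14% to 34%.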

Compound 4, a percentage reported as activity, at one dose (the size of the read-out at that dose, not a potency): 10.9%
Compound 4: middle estimate off by 13.1 percentage points, on the high side; the measured number lies below the stated range.
By their numbers in this assay, from the lowest: compounds 4, 3, 2 and 1 (each within the scatter of the next, the first and the last beyond it).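

In this assay this carbon gives its first steps beyond the scatter, both with 1-hydroxyethyl entering: a number 11.4 percentage points lower from compound 2 to compound 4 (beyond the scatter) and a number 14.9 percentage points lower from compound 1 to compound 4 (beyond the scatter). Against 2-(benzyloxycarbonyl)ethyl the same group gives a number 9.8 percentage points lower from compound 3 to compound 4 (within the scatter), so compound 3 and compound 4 cannot be told apart despite the loss of the aromatic ring. No measurement on hand accounts for these steps. Still open, from the compounds shown here alone, is whether the hydroxyl of 1-hydroxyethyl or its defined stereocentre carries the steps, and how a plain ethyl or a carboxylic acid on this carbon would read.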